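This account rests on a few compounds, and the source may have more. Where it says the series, first, only, none or still open, it means among the compounds named here.

Measured compounds:
compound 1 `CCc1cc(C)c(C(=O)N=C(N)N)cc1S(C)(=O)=O` — 4.8 nM
compound 2 `Cc1cc(OC(C)(C)C)c(S(C)(=O)=O)cc1C(=O)N=C(N)N` — 9.4 nM

In a functional assay for inhibition of sodium/hydrogen exchanger (Oryctolagus cuniculus) (a lower number here means a stronger inhibitor, a higher number a weaker inhibitor), compound 1 gives 4.8 nM, and compound 2 gives 9.4 nM, the higher of the two numbers, though the step of a 2.0-fold higher number from compound 1 to compound 2 (0.29 log units; within the scatter) stays within the scatter, so the two compounds cannot be ranked against each other. Compound 3 `Cc1cc(N2CCC(N)CC2)c(S(C)(=O)=O)cc1C(=O)N=C(N)N` has not yet been measured. It differs from compound 2 by 4-aminopiperidin-1-yl in place of tert-butoxy on an aromatic carbon. Within the data shown here, the only measured step, a 2.0-fold higher number from compound 1 to compound 2 (0.29 log units; within the scatter), concerns a different replacement at the same aromatic carbon and was too small to show a direction, so no measured step bears directly on the entry of the 4-aminopiperidin-1-yl group. With two compounds that sit close together, the expectation for compound 3 in this assay is an estimated step of a 1.6-fold higher number from compound 2 to compound 3 (0.20 log units; within the scatter), with wide uncertainty in both directions. Compound 3 is therefore expected to give about 15 nM, within a range from 4 nM to 60 nM.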

Compound 3, half-maximal inhibitory concentration: 9.8 nM
The estimate for compound 3 lay 1.5-fold (0.18 log units) above the measured number, and the stated range covers the measured number.
By their numbers in this assay, from the lowest: compounds 1, 2 and 3 (each within the scatter of the next, the first and the last beyond it).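

In this assay the replacement of tert-butoxy gives a 1.0-fold higher number from compound 2 to compound 3 (0.02 log units; within the scatter) and so shows that this aromatic carbon, ortho to a methylsulfonyl group, can carry a six-membered non-aromatic ring with a hydrogen-bond donor and still give a number in the same range as compound 2. Set against ethyl, the same group gives a 2.0-fold higher number from compound 1 to compound 3 (0.31 log units; beyond the scatter) and this modest step is the only one among the three compounds that lies beyond the scatter, while compound 2 stays within the scatter of both neighbours.

From the compounds shown here alone, whether the amine on the ring matters at this position stays open, and a plain piperidin-1-yl group or a morpholine ring in its place would speak to that question. Also open, going by these compounds, is how a longer chain ending in an amine would read here. No supporting measurement bears on this result.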